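Removal of the second methoxy from the quinazoline-free core

A few compounds are considered here, and "the series" means these few. Any claim that something is new, unique, unknown or untested is made for them only; others in the source may bear on it.

Of the compounds shown here, two have numbers so far. Compound 1 `COc1cc2ncnc(Oc3ccc(F)cc3F)c2cc1OC` gives 1200 nM in an assay on HEK293-TREx cells for antagonist activity at transient receptor potential cation channel subfamily A member 1 (Homo sapiens), read by fluorescence and calcium flux, with a stated time of 72 h (a lower number here means a stronger inhibitor, a higher number a weaker inhibitor), and stands lowest of the two; its nearest neighbour is compound 2 `COc1ccc2c(Oc3ccc(F)cc3F)ncnc2c1`, which in this assay gives 3000 nM. Among the compounds with values here, the one measured step is a 2.5-fold higher number from compound 1 to compound 2 (0.40 log units; beyond the scatter), a loss of a methoxy from the shared core.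

Compound 3 `COc1ccc2ncnc(Oc3ccc(F)cc3F)c2c1` is the untested partner. Within the data shown here, it differs from compound 1 by hydrogen in place of methoxy on an aromatic carbon; the methoxy that goes is the other one of the pair on the core, the one that stayed in compound 2.

Among the measured compounds shown here, the only step that bears on this is a 2.5-fold higher number from compound 1 to compound 2 (0.40 log units; beyond the scatter), where dropping a methoxy from the same core cost potency in a modest but real way. The same kind of change is therefore expected to give a similar step here: compound 3 is estimated at 2500 nM (range 1000 nM to 6000 nM), meaning an expected step of a 2.1-fold higher number from compound 1 to compound 3 (0.32 log units; beyond the scatter).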

Compound 3, half-maximal inhibitory concentration: > 32000 nM
Compound 3 was reported as a limit; the forecaster's own chance of this, stated with the estimate: 5%; middle value at least 12-fold (1.10 log units) from the limit.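

In this assay compound 3 stands only as a limit, not as a number: the limit of > 32000 nM in this assay, at which 1 of the 3 values shown sits.

Hydrogen in place of methoxy at this position gives an at least 26-fold higher number from compound 1 to compound 3 (1.42 log units; beyond the scatter), whereas the same change at the other methoxy gives a 2.5-fold higher number from compound 1 to compound 2 (0.40 log units; beyond the scatter). Within the data shown here, the two methoxy groups of compound 1 therefore do not count alike, and the loss of the one absent from compound 3 costs far more, which the single earlier step could not show.

From the compounds shown here alone, how far compound 3 lies past its limit remains open, so the size of this step has only a lower bound. The compounds shown also leave open whether a hydroxyl, an ethoxy or a longer alkoxy chain at this position would keep the potency of compound 1.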